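Fluoro on compound 2 in a series at the limit

The compounds below may be only part of what the source reports. "The series", "measured", "known", "first", "only" and "open" are said of these compounds alone.

In an ADME assay on T29 cells (Homo sapiens) for cytotoxicity, read by sulforhodamine B assay, with a stated time of 3 days (a lower number here means a stronger inhibitor, a higher number a weaker inhibitor), compound 2 `Cc1ccc(Cn2cc(CO)c3ccccc32)cc1` gives > 31600 nM, a limit and not a number. Compound 1 `OCc1cn(Cc2ccc(Br)cc2)c2ccccc12` gives > 31600 nM, also a limit. Compound 3 `COc1ccc(Cn2cc(CO)c3ccccc32)cc1` gives > 31600 nM, again a limit. Among the measured compounds shown here, the series so far shows (the limit of > 31600 nM in this assay, at which 3 of the 3 values shown sit). The measured steps are a step that the two limits leave unreadable from compound 1 to compound 2, a step that the two limits leave unreadable from compound 1 to compound 3 and a step that the two limits leave unreadable from compound 2 to compound 3. Compound 4 `Cc1ccc(Cn2cc(CO)c3cc(F)ccc32)cc1` differs from compound 2 by fluoro in place of hydrogen on an aromatic carbon. For the measured compounds named here, none of the measured steps changes that carbon, and none has a readable size, so they give no measure for this change. No step beyond the scatter is expected in this assay, and the expected step is a number no higher from compound 2 to compound 4 (the limit leaves the size open). For compound 4 the estimate is 31600 nM, with an expected range of 10000 nM to 60000 nM.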

Compound 4, half-maximal inhibitory concentration: 11700 nM
Estimate against measurement, compound 4: 2.7-fold (0.43 log units) above, within the range that was stated.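

In this assay, among the compounds shown here, fluoro in place of hydrogen on this aromatic carbon gives an at least 2.7-fold lower number from compound 2 to compound 4 (0.43 log units; beyond the scatter), the first readable step, and its full size stays open. The steps among compound 1, compound 2 and compound 3 cannot be read. Compound 4 alone leaves the limit that holds the rest of the series: the limit of > 31600 nM in this assay, at which 3 of the 4 values shown sit.

From the compounds shown here alone, whether fluoro at this carbon has the same effect with the bromo or methoxy group of compound 1 or compound 3 remains open. So does the outcome with an amine or a carboxylic acid at this carbon.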